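The compounds below may be only part of what the source reports. "The series", "measured", "known", "first", "only" and "open" are said of these compounds alone.

Compound 1 `COC(=O)C1=C(C)NC(=O)NC1c1cccs1` gives 3% in an assay on membranes from HeLa cells for displacement of a labelled ligand from adenosine receptor A3 (Homo sapiens), read by scintillation counting, with a stated time of 180 min, tested at 1 uM; on this read-out lower numbers stand for less inhibition and higher numbers for more inhibition at the one concentration tested (going by the name of the read-out). Compound 2 `CCCOC(=O)C1=C(C)NC(=O)NC1c1cccs1` gives 32% in this assay; the change ethyl in place of hydrogen on a saturated chain carbon bound to an oxygen next to a carbonyl group made the step of a number 29 percentage points higher from compound 1 to compound 2 (beyond the scatter). Compound 3 `COC(=O)C1=C(C)NC(=S)NC1c1ccsc1` rests on another core; the difference between the two cores is not broken down here. In this assay compound 3 gives 3%, level with compound 1 and, with it, the lowest of the three numbers. Compound 4 `CCCOC(=O)C1=C(C)NC(=S)NC1c1ccsc1` carries the same change on this core, (ethyl in place of hydrogen on a saturated chain carbon bound to an oxygen next to a carbonyl group), at the same place. Among the compounds with values here, the measured pair from compound 1 to compound 2 is the only guide to the size of this change here. For compound 4 a step of about a number 24 percentage points higher from compound 3 to compound 4 (beyond the scatter) is expected in this assay, resting on the step of a number 29 percentage points higher from compound 1 to compound 2 (beyond the scatter). The estimate for compound 4 is therefore 27%, between 8% and 48%.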

Compound 4, a percentage reported as inhibition, at one concentration (the size of the read-out at that concentration, not a potency): 1%
Compound 4: middle estimate off by 26 percentage points, on the high side, outside the stated range (below it).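

Moving from methoxycarbonyl to propoxycarbonyl does not carry over between the two cores in this assay: the rise seen on the core of compound 1 does not appear on the other core, where the same change gives a number 2 percentage points lower from compound 3 to compound 4 (within the scatter). The step therefore cannot be taken as a fixed increment across these two cores: the same change on two cores in this assay, a number 29 percentage points higher (beyond the scatter) from compound 1 to compound 2 and a number 2 percentage points lower (within the scatter) from compound 3 to compound 4, 31 percentage points apart, beyond the scatter of two such steps. This does not show which part of the difference between the cores matters, and one pair per core gives no rule for any further core.

From the compounds shown here alone, a longer chain, such as butoxycarbonyl, remains open on both cores. So does a carboxylic acid or an amide in place of the propoxycarbonyl group.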